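A Second Chlorine on the Pendant Ring

A few compounds are considered here, and "the series" means these few. Any claim that something is new, unique, unknown or untested is made for them only; others in the source may bear on it.

Going by the values given here, in an assay on isolated protein (Aquatica lateralis) for inhibition of Luciferin 4-monooxygenase (Luciola lateralis), read by a luciferase reporter, tested at 10 uM (on this read-out lower numbers stand for less inhibition and higher numbers for more inhibition at the one concentration tested (going by the name of the read-out)), compound 1 `O=C(Nc1ccccn1)c1ccccc1` gives 27%, and compound 2 `O=C(Nc1ccc(-c2cccc(Cl)c2)cn1)c1ccccc1` gives 38%, the higher of the two numbers measured so far; the step of a number 11 percentage points higher from compound 1 to compound 2 (beyond the scatter) lies beyond the scatter. Compound 3 `O=C(Nc1ccc(-c2ccc(Cl)c(Cl)c2)cn1)c1ccccc1` differs from compound 2 by chloro in place of hydrogen on an aromatic carbon. Among the compounds with values here, no measured step adds a second chloro group to a ring that already carries one, so the only guide is the modest rise seen on introducing the 3-chlorophenyl group. A small step is therefore expected, a number 4 percentage points higher from compound 2 to compound 3 (within the scatter), probably within the scatter. Compound 3 is estimated to give 42%, with a range from 28% to 58%.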

Compound 3, a percentage reported as inhibition, at one concentration (the size of the read-out at that concentration, not a potency): 4%
Beside the measured number, compound 3's estimate is 38 percentage points above it; measured number below the stated range.
By their numbers in this assay, from the lowest: compound 3; then compound 1; then compound 2.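

In a number 34 percentage points lower from compound 2 to compound 3 (beyond the scatter) of this assay, one added chloro, on the aromatic carbon ortho to a chloro group and para to a large group, brings a large fall. So this position is not indifferent to a single heavy atom, and the gain seen with the 3-chlorophenyl group does not extend to a second chloro here. Nothing available explains this fall. Still open, on these data alone, is whether a methyl or a methoxy group at this position would bring a similar fall, or whether it belongs to chloro alone.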